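Swapping the acyl ring: fluorophenyl to furan

This account rests on a few compounds, and the source may have more. Where it says the series, first, only, none or still open, it means among the compounds named here.

Compound 1, `CNc1cc(C)c2cc(NC(=O)c3ccc(Cl)c(Cl)c3)ccc2n1`, gives 2520 nM in a functional assay on MCF7 cells (Homo sapiens) for antiproliferative activity, read by MTT assay, with a stated time of 72 h; a higher number here means a weaker inhibitor, a lower number a stronger inhibitor. Going by the values given here, compound 2, `Cc1cc(N2CCCC2)nc2ccc(NC(=O)c3ccc(Cl)c(Cl)c3)cc12`, gives 26300 nM in this assay, and the single change between them reads a 10-fold higher number from compound 1 to compound 2 (1.02 log units; beyond the scatter). Compound 3, `CCN1CCN(c2cc(C)c3cc(NC(=O)c4ccccc4F)ccc3n2)CC1`, gives 32600 nM in this assay; this number is beyond the scatter from that of compound 1 and within the scatter of that of compound 2, so no order between compound 3 and compound 2 can be read from these figures.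

Compound 4, `CCN1CCN(c2cc(C)c3cc(NC(=O)c4ccco4)ccc3n2)CC1`, differs from compound 3 in one place: furan-2-yl in place of 2-fluorophenyl on a carbonyl carbon, on a carbonyl carbon whose other neighbour is an amide-type nitrogen. Among the compounds with values here, the only measured step, from compound 1 to compound 2, alters the amine on the shared core rather than the acyl ring, so no measured step bears on this change; compound 2 and compound 3 differ in two places and give no step. With nothing pointing either way, no step beyond the scatter is expected. Compound 4 is therefore estimated at 30000 nM, between 10000 nM and 90000 nM. This corresponds to an expected step of a 1.1-fold lower number from compound 3 to compound 4 (0.04 log units; within the scatter).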

Compound 4, half-maximal inhibitory concentration: 41200 nM
Compound 4: the middle estimate sits 1.4-fold (0.14 log units) below what was measured, and the stated range covers the measured number.
By their numbers in this assay, from the lowest: compound 1; then compounds 2, 3 and 4 (each within the scatter of the next).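

In this assay, going by these compounds alone, furan-2-yl in place of 2-fluorophenyl on the carbonyl carbon gives a 1.3-fold higher number from compound 3 to compound 4 (0.10 log units; within the scatter), the first measured step at the acyl ring, so these two rings cannot be told apart here. Within the data shown here, the only earlier step, a 10-fold higher number from compound 1 to compound 2 (1.02 log units; beyond the scatter), lay at the amine on the shared core, and it alone gave no reading on the acyl ring. No measurement at hand accounts for this result.

The compounds shown leave open whether furan-2-yl and 2-fluorophenyl would also read alike with methylamino or pyrrolidin-1-yl on the core. They also leave open whether a pyridine ring or a longer alkyl chain on the same carbonyl carbon would give a step beyond the scatter.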